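This account rests on a few compounds, and the source may have more. Where it says the series, first, only, none or still open, it means among the compounds named here.

Measured so far in an ADME assay on HeLa cells (Homo sapiens) for cytotoxicity, read by ATP content, with a stated time of 3 days; on this read-out higher numbers stand for lower toxicity in this test and lower numbers for higher toxicity in this test:

- compound 1 `CC(C)CCn1c(Cn2c(=O)n(C3CC3)c3ccncc32)nc2nc(Cl)ccc21`: > 50000 nM
- compound 2 `O=c1n(Cc2nc3nc(Cl)ccc3n2CCCCO)c2cnccc2n1C1CC1`: > 50000 nM
- compound 3 `O=c1n(Cc2nc3cnccc3n2CCCCO)c2cnccc2n1C1CC1`: > 100000 nM

Each of these values is a limit of this assay, not a number. Compound 1 sits at the limit of > 50000 nM in this assay, at which 2 of the 3 values shown sit. Compound 2 also sits at that limit. Compound 3 sits at the limit of > 100000 nM in this assay, at which 1 of the 3 values shown sits. Among the measured compounds shown here, no compound of the three reaches a numerical half-maximal cytotoxic concentration within the tested range.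

Compound 1 and compound 2 differ by isopropyl in place of 2-hydroxyethyl on a saturated chain carbon, two bonds along the chain from an aromatic nitrogen. The step that the two limits leave unreadable from compound 2 to compound 1 cannot be read in size, since both ends are limits; all that is shown is that neither compound reaches a measurable cytotoxic concentration. Compound 2 and compound 3 carry different cores; the difference between the two cores is not broken down here, and their two values are both limits.

Compound 4 `CC(C)CCn1c(Cn2c(=O)n(C3CC3)c3ccncc32)nc2cnccc21` is not yet measured in this assay. It differs from compound 3 by isopropyl in place of 2-hydroxyethyl on a saturated chain carbon, two bonds along the chain from an aromatic nitrogen, the same change that separates compound 2 from compound 1. Compound 4 shares its core with compound 3.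

For compound 4 the step of a number no higher from compound 3 to compound 4 (the limit leaves the size open) is expected to be small, resting on compound 3, whose value > 100000 nM is a limit, and on the pair compound 2 and compound 1, which both remain at a limit across the same change. Compound 4 is therefore estimated at 100000 nM, with a range from 50000 nM to 300000 nM, and most likely the assay will again report only a limit.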

Compound 4, half-maximal cytotoxic concentration: > 100000 nM
Compound 4: only a limit was reported; the forecaster's own chance of this, stated with the estimate: 85%; the middle value lies on the limit itself.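

In this assay compound 4 gives > 100000 nM, a limit of the assay and not a number. With compound 3 also at a limit, no step can be read between compound 3 and compound 4. The compounds shown leave open where any of the four would reach a numerical half-maximal cytotoxic concentration, and what isopropyl in place of 2-hydroxyethyl would do to such a value.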